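Ester Side Chain and Plasma Stability in a Shared Core

The source may hold more compounds than are shown below. What is called first, only, known or untested is meant among the compounds shown, and "the series" means these compounds.

Measured compounds:
compound 1 `CCCCC(=O)O[C@@H]1CO[C@H]2[C@@H]1OC[C@@H]2OC(=O)c1ccccc1OC(C)=O` — 0.0117 h
compound 2 `CC(=O)Oc1ccccc1C(=O)O[C@H]1CO[C@H]2[C@@H]1OC[C@H]2OC(=O)c1cccc(C)c1` — 0.0203 h
compound 3 `CC(=O)Oc1ccccc1C(=O)O[C@H]1CO[C@H]2[C@@H]1OC[C@H]2OC(=O)c1ccc(-c2ccccc2)cc1` — > 0.333 h

The three measured compounds share a core and differ only in the acyl group on one of its oxygens. In an ADME assay on a cell-free system (plasma, Homo sapiens) for metabolic stability, with Plasma (Rattus norvegicus) as the target, read by HPLC, at pH 7.4 (a higher number here means that the compound lasts longer, a lower number that the compound disappears faster), compound 1 gives 0.0117 h. Compound 2 gives 0.0203 h in this assay, and the step of a 1.7-fold higher number from compound 1 to compound 2 (0.24 log units; within the scatter) stays within the scatter. Compound 3 reached a limit of this assay, > 0.333 h, so only a limit is known for it and the true half-life lies beyond that value (the limit of > 0.333 h in this assay, at which 1 of the 3 values shown sits). The steps of an at least 28-fold higher number from compound 1 to compound 3 (1.45 log units; beyond the scatter) and an at least 16-fold higher number from compound 2 to compound 3 (1.21 log units; beyond the scatter) are both large and beyond the scatter, and both come from entry of the 4-phenylphenyl group.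

Compound 4 `CC(=O)Oc1ccccc1C(=O)O[C@H]1CO[C@H]2[C@@H]1OC[C@H]2OC(=O)c1cnccc1Cl` has not yet been measured. It differs from compound 3 by the change (4-chloropyridin-3-yl in place of 4-phenylphenyl on a carbonyl carbon). Since the 4-phenylphenyl group leaves again, the steps that brought compound 3 to its limit are expected to run backwards in some measure. Compound 2 gives 0.0203 h in this assay and is the closest measured point of comparison. Compound 4 is therefore expected to fall well below the limit, with an estimated half-life of 0.03 h, between 0.01 h and 0.12 h. The step of an at least 11-fold lower number from compound 3 to compound 4 (1.04 log units; beyond the scatter) is expected to be a large decrease.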

Compound 4, half-life: 0.0322 h
For compound 4 the middle estimate is 1.1-fold (0.03 log units) below the measured one; the range from low to high includes it.
By their numbers in this assay, from the lowest: compounds 1, 2 and 4 (each within the scatter of the next, the first and the last beyond it). At a limit, above all of these: compound 3.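

Putting 4-chloropyridin-3-yl in place of 4-phenylphenyl on the carbonyl carbon gives an at least 10-fold lower number from compound 3 to compound 4 (1.01 log units; beyond the scatter) in this assay, so the large gain at this position does not carry over to this single-ring group, which has one ring nitrogen and a chlorine. Compound 3 stands at a limit of the assay, so the size of that step is known only as a bound: the limit of > 0.333 h in this assay, at which 1 of the 4 values shown sits.

Set against the other acyl groups, the same group gives a 1.6-fold higher number from compound 2 to compound 4 (0.20 log units; within the scatter) and a 2.8-fold higher number from compound 1 to compound 4 (0.44 log units; beyond the scatter), so 4-chloropyridin-3-yl shows only a modest difference from butyl, and 4-phenylphenyl remains the only group shown with a large step at this position.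

The compounds shown leave open whether the large step depends on the second carbon ring of 4-phenylphenyl, a question that a plain phenyl, a 4-methoxyphenyl or a 4-phenoxyphenyl group on the same carbonyl carbon would address. They also leave open how the ring nitrogen and the chlorine of compound 4 each count on their own, and whether a longer alkyl chain would differ from butyl.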